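Oxime ether geometry at a dopamine D4 receptor series

The source may report more compounds than this note shows. Statements on the series, on what has been measured and on what is new or still open speak of the compounds shown alone.

Measured compounds:
compound 1 `Cc1ccccc1/C(CCN1CCN(c2ccccn2)CC1)=N\O`: 20.3 nM
compound 2 `CO/N=C(\CCN1CCN(c2ccccn2)CC1)c1ccccc1C`: 74 nM

In a functional assay on HEK293 cells with D(4) dopamine receptor (Homo sapiens) as the target, read by FLIPR (a lower number here means that less compound is needed, a higher number that more compound is needed for the effect), compound 2 gives the highest of the two numbers, with compound 1 as its nearest neighbour, a gap beyond the scatter. Compound 3 `CO/N=C(/CCN1CCN(c2ccccn2)CC1)c1ccccc1C` differs from compound 2 in one respect: the two compounds have the same atoms and bonds and differ only in configuration as drawn: 1 of 1 stereo elements differ; a double bond is drawn E in compound 2 and Z in compound 3. Within the data shown here, no measured pair shows what this change does here, so the direction is open; a step of the size seen between compound 1 and compound 2 is plausible either way, with no change beyond the scatter also possible. Compound 3 is expected to give 100 nM (range 25 nM to 400 nM), an expected step of a 1.4-fold higher number from compound 2 to compound 3 (0.13 log units; within the scatter).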

Compound 3, half-maximal effective concentration: 40.1 nM
For compound 3 the middle estimate is 2.5-fold (0.40 log units) above the measured one; the measured number falls inside the stated range.
By their numbers in this assay, from the lowest: compounds 1, 3 and 2 (each within the scatter of the next, the first and the last beyond it).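

In this assay, the change of the double bond from E to Z gives a 1.8-fold lower number from compound 2 to compound 3 (0.27 log units; within the scatter), so at this position configuration alone shifts the number by no more than the scatter: the fact that compounds 2 and 3 differ only in the configuration as drawn. With the Z configuration held, methyl in place of hydrogen on an oxygen gives a 2.0-fold higher number from compound 1 to compound 3 (0.30 log units; within the scatter), which also lies within the scatter.

The compounds shown leave open how an ethyl or benzyl group on that oxygen would read. They also leave open whether either change would matter with a longer chain in the core.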